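No number yet: both triazole-series compounds sit at the limit

The source may report more compounds than this note shows. Statements on the series, on what has been measured and on what is new or still open speak of the compounds shown alone.

compound 1 `CCc1nnc(SCC(=O)c2ccc(Cl)cc2)n1N1C(=O)c2ccccc2C1=O`: > 200000 nM
compound 2 `C=CCSc1nnc(CCC)n1N1C(=O)c2ccccc2C1=O`: > 200000 nM

In a functional assay on HepG2 cells (Homo sapiens) for cytotoxicity, read by MTT assay, with a stated time of 48 h (a higher number here means a weaker inhibitor, a lower number a stronger inhibitor), compound 2 gives only a limit, > 200000 nM. Compound 1 also gives a limit in this assay, > 200000 nM. Both therefore stand at the limit of > 200000 nM in this assay, at which 2 of the 2 values shown sit. Compound 3 `CCCc1nnc(SCC(=O)c2ccc(Cl)cc2)n1N1C(=O)c2ccccc2C1=O` differs from compound 2 by (4-chlorophenyl)carbonyl in place of vinyl on a saturated chain carbon bound to a sulfur. For the measured compounds named here, no measured step connects such a change here, so the expectation rests on the fact that compound 3 is close in shape to compound 1 and because compound 1 sits at the limit of > 200000 nM in this assay, at which 2 of the 2 values shown sit. No step beyond the usual scatter is expected; the expected step is a step that the limit leaves unreadable from compound 2 to compound 3. Compound 3 is estimated at 300000 nM, between 100000 nM and 1000000 nM, most likely again reported only as a limit.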

Compound 3, half-maximal inhibitory concentration: > 200000 nM
Compound 3: only a limit was reported; the forecaster's own chance of this, stated with the estimate: 90%; the middle value lies beyond the limit too.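

In this assay compound 1, compound 2 and compound 3 allow no readable step, each value being only a limit: the limit of > 200000 nM in this assay, at which 3 of the 3 values shown sit.

Going by these compounds, whether any change to the groups on the shared core would give a measurable value stays open.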